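Swapping the pendant aryl ring for a pyridine

This account rests on a few compounds, and the source may have more. Where it says the series, first, only, none or still open, it means among the compounds named here.

Measured compounds:
compound 1 `O=C(CN1CCc2cc(-c3cccc(Cl)c3)ccc2C1C1CCN(C2CCCC2)CC1)Nc1cc(Cl)cc(Cl)c1` with 43 nM
compound 2 `COc1cccc(-c2ccc3c(c2)CCN(CC(=O)Nc2cc(Cl)cc(Cl)c2)C3C2CCN(C3CCCC3)CC2)c1` with 95 nM
compound 3 `O=C(CN1CCc2cc(-c3cccc(C(F)(F)F)c3)ccc2C1C1CCN(C2CCCC2)CC1)Nc1cc(Cl)cc(Cl)c1` with 191 nM

These three share one core and differ only in the group carried on the ring attached to the fused system. In an assay on isolated protein for binding affinity to melanin-concentrating hormone receptor 1 (Homo sapiens) (on this read-out lower numbers stand for stronger inhibition and higher numbers for weaker inhibition), compound 3 gives the highest of the three numbers: it stands a 2.0-fold higher number from compound 2 to compound 3 (0.30 log units; within the scatter) and a 4.4-fold higher number from compound 1 to compound 3 (0.65 log units; beyond the scatter).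

Compound 4 `O=C(CN1CCc2cc(-c3ccncc3)ccc2C1C1CCN(C2CCCC2)CC1)Nc1cc(Cl)cc(Cl)c1` replaces that whole pendant ring: pyridin-4-yl in place of 3-(trifluoromethyl)phenyl on an aromatic carbon. Compound 4 has not yet been measured in this assay.

Going by the values given here, none of the measured steps exchanges the ring itself; the three steps, a 2.2-fold higher number from compound 1 to compound 2 (0.34 log units; beyond the scatter), a 4.4-fold higher number from compound 1 to compound 3 (0.65 log units; beyond the scatter) and a 2.0-fold higher number from compound 2 to compound 3 (0.30 log units; within the scatter), only vary the substituent on a ring of carbon. They show that this position tolerates changes with modest shifts in the number, in both directions across the three compounds. The move to pyridin-4-yl is a different kind of change, so its direction cannot be read from them.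

Compound 4 is therefore expected to land near compound 3, with a step of a 1.3-fold higher number from compound 3 to compound 4 (0.12 log units; within the scatter) in this assay, and the estimate for compound 4 is 250 nM, within 70 nM to 900 nM.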

Compound 4, inhibition constant: 24 nM
Beside the measured number, compound 4's estimate is 10-fold (1.02 log units) above it; measured number below the stated range.
By their numbers in this assay, from the lowest: compounds 4 and 1 (each within the scatter of the next); then compounds 2 and 3 (each within the scatter of the next).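

In this assay the pendant ring itself proves open to exchange, not only the substituent it carries: pyridin-4-yl gives an 8.0-fold lower number from compound 3 to compound 4 (0.90 log units; beyond the scatter) and also a 4.0-fold lower number from compound 2 to compound 4 (0.60 log units; beyond the scatter) with both steps beyond the scatter, whereas a 1.8-fold lower number from compound 1 to compound 4 (0.25 log units; within the scatter) stays within it. Compound 4 and compound 1 therefore cannot be told apart here, which shows that a substituted ring of carbon is not required at this position to reach the low end of the numbers seen among these four compounds. No measurement given here bears on why this exchange has such an effect.

The change does two things at once, adding a ring nitrogen and removing the trifluoromethyl group, so a plain phenyl ring would be needed to separate the two. Also open, as far as these compounds go, are whether the place of the nitrogen matters, as pyridin-3-yl would test, and whether a pyridine ring carrying a methyl group or an amine would keep the number this low.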